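A few compounds are considered here, and "the series" means these few. Any claim that something is new, unique, unknown or untested is made for them only; others in the source may bear on it.

Measured in a functional assay on U-87MG ATCC cells (Homo sapiens) for cytotoxicity, read by MTT assay, with a stated time of 48 h; a lower number here means a stronger inhibitor, a higher number a weaker inhibitor:
compound 1 `C/C(=N\NC(=S)Nc1ccc(I)cc1)c1ccccn1` gives 59 nM
compound 2 `CC(=NNC(=S)Nc1ccccc1)c1ccccn1` gives 1.4 nM
compound 3 `C/C(=N\NC(=S)Nc1ccccc1F)c1ccccn1` gives 5 nM

Compound 1 at 59 nM stands highest of the three and is the weakest inhibitor so far. Compound 3 at 5 nM and compound 2 at 1.4 nM both lie lower, each beyond the scatter of repeated measurements.

Next is compound 4 `C/C(=N\NC(=S)Nc1ccc([N+](=O)[O-])cc1)c1ccccn1` which has not yet been measured. It differs from compound 1 by nitro in place of iodo on an aromatic carbon with nitro in place of iodo on an aromatic carbon, para to a large group.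

Among the compounds with values here, no two measured compounds differ in one place only, so the series offers no direct measure of this change. Within the data shown here, the only guide is the spread of values: compound 1 at 59 nM sits well above compound 3 at 5 nM and this leaves more room for a fall than for a rise. A move to a lower number, probably beyond the scatter, is therefore expected, and the estimated change is a 4.9-fold lower number from compound 1 to compound 4 (0.69 log units; beyond the scatter) with wide uncertainty. Compound 4 is estimated at 12 nM with an expected range of 2 nM to 70 nM for the measurement still to come.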

Compound 4, half-maximal inhibitory concentration: 160 nM
For compound 4 the middle estimate is 13-fold (1.12 log units) below the measured one; measured number outside the range, above it.
By their numbers in this assay, from the lowest: compound 2; then compound 3; then compound 1; then compound 4.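

In this assay, within the data shown here, the exchange of iodo for nitro on an aromatic carbon, para to a large group, gives the first step that can be read at one place: a 2.7-fold higher number from compound 1 to compound 4 (0.43 log units; beyond the scatter) is a modest rise, yet it lies beyond the scatter. The position is therefore not indifferent to the group it carries, and within this pair nitro gives the weaker inhibitor and iodo the stronger. No measured property of either group is available to account for this rise.

Among these compounds, with only two groups compared at this position, a single step says nothing about a trend, and it cannot be told whether the rise belongs to nitro alone or would extend to other groups placed there. The compounds shown leave open how an amine or a carboxylic acid at the same aromatic carbon would compare with iodo and nitro on the core of compound 1.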